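A few compounds are considered here, and "the series" means these few. Any claim that something is new, unique, unknown or untested is made for them only; others in the source may bear on it.

Compound 3 `COc1cc(Cl)cc(-c2nn(-c3cccc(NC(=O)Nc4cc(C(F)(F)F)cc(C(F)(F)F)c4)c3)cc2-c2ccncc2)c1` gives 93% in a functional assay on NCI-H522 cells (Homo sapiens) for inhibition, read by sulforhodamine B assay, with a stated time of 48 h, tested at 0.01 uM; a lower number here means a stronger effect, a higher number a weaker effect of the compound at the concentration tested. Compound 2 `COc1cc(Cl)cc(-c2nn(-c3cccc(NC(=O)Nc4ccc(Cl)c(C(F)(F)F)c4)c3)cc2-c2ccncc2)c1` gives 93%, level with compound 3; together they stand highest of the three, and compound 1 `O=C(Nc1cccc(-n2cc(-c3ccncc3)c(-c3cc(O)cc(Cl)c3)n2)c1)Nc1ccc(Cl)c(C(F)(F)F)c1` gives 56%, the lowest. For the measured compounds named here, the one step that is directly comparable, a number 37 percentage points higher from compound 1 to compound 2 (beyond the scatter), changes a methyl on an oxygen of the shared core and does not touch the urea-bearing ring. Compound 4 `COc1cc(Cl)cc(-c2nn(-c3cccc(NC(=O)Nc4cccc(C(F)(F)F)c4)c3)cc2-c2ccncc2)c1` differs from compound 3 by hydrogen in place of trifluoromethyl on an aromatic carbon. Going by the values given here, no measured step changes that part of the molecule, though compound 2 and compound 3 differ there and show values within the scatter of each other. Compound 4 is therefore expected to shift by about a number 5 percentage points lower from compound 3 to compound 4 (within the scatter) in this assay, nothing beyond the scatter. Compound 4 is estimated at 88%, within 70% to 100%.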

Compound 4, a percentage reported as activity, at one concentration (the size of the read-out at that concentration, not a potency): 95%
Compound 4: the middle estimate sits 7 percentage points below what was measured; measured number inside the range.
By their numbers in this assay, from the lowest: compound 1; then compounds 2, 3 and 4 (each within the scatter of the next).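

Hydrogen in place of trifluoromethyl gives a number 2 percentage points higher from compound 3 to compound 4 (within the scatter) in this assay, and hydrogen in place of chloro gives a number 2 percentage points higher from compound 2 to compound 4 (within the scatter). Among these three compounds, then, the extra trifluoromethyl or chloro on the urea-bearing ring makes no difference beyond the scatter. Nothing measured here offers an explanation for this.

On these data alone, all three compounds carry the methyl on the oxygen, so it remains open whether these changes would matter in compound 1, with its free hydroxyl. Also open, as far as these compounds go, is what an amine or a carboxylic acid would do at this position.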